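A few compounds are considered here, and "the series" means these few. Any claim that something is new, unique, unknown or untested is made for them only; others in the source may bear on it.

Working notes on the thiourea series in an assay on CHO cells for displacement of a labelled ligand from transient receptor potential cation channel subfamily V member 1 (Rattus norvegicus); on this read-out lower numbers stand for stronger inhibition and higher numbers for weaker inhibition.

Compound 3 `COc1cc(CNC(=S)NCC(COC(=O)C(C)(C)C)Cc2ccc(C)c(C)c2)cc(Cl)c1O` gives 30.9 nM in this assay. Among the three measured compounds it stands second highest. Compound 1 `COc1cc(CNC(=S)NC(CCc2ccc(C(C)(C)C)cc2)COC(=O)C(C)(C)C)ccc1O` gives 36.5 nM, a number within the usual scatter of that of compound 3, so the two cannot be ordered. Compound 2 `COc1cc(CNC(=S)NCC(COC(=O)C(C)(C)C)Cc2ccc(C(C)(C)C)cc2)c(I)cc1O` gives 13.3 nM, a number lower than that of compound 3 beyond the scatter; compound 2 differs from compound 3 in more than one place, so its value is noted only as the strongest inhibition seen so far in this assay.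

Compound 4 `COc1cc(CNC(=S)NCC(COC(=O)C(C)(C)C)Cc2ccc(C)c(C)c2)c(Cl)cc1O` has not been measured in this assay. It differs from compound 3 by 2-chloro-4-hydroxy-5-methoxyphenyl in place of 3-chloro-4-hydroxy-5-methoxyphenyl on a saturated chain carbon bound to an amide-type nitrogen; the two have the same atoms, joined differently. Among the compounds with values here, no pair of measured compounds differing in one place is available, so no measured step guides the expectation. With the whole remainder of the molecule unchanged, the step from compound 3 to compound 4 is expected to be small, a 1.2-fold lower number from compound 3 to compound 4 (0.09 log units; within the scatter), and not beyond the scatter in either direction. Compound 4 is therefore estimated at 25 nM in this assay, with a range from 9 nM to 70 nM.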

Compound 4, inhibition constant: 24.2 nM
Estimate against measurement, compound 4: 1.0-fold (0.01 log units) above; the measured number falls inside the stated range.
By their numbers in this assay, from the lowest: compounds 2, 4, 3 and 1 (each within the scatter of the next, the first and the last beyond it).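

The step gives the series its first reading of a single change: with the rest of the molecule unchanged, 2-chloro-4-hydroxy-5-methoxyphenyl in place of 3-chloro-4-hydroxy-5-methoxyphenyl in this assay gives a 1.3-fold lower number from compound 3 to compound 4 (0.11 log units; within the scatter), so the two arrangements of the same atoms cannot be ordered on this read-out. At this place, then, moving from one of these chlorinated rings to the other leaves the number unresolved from the scatter, something compounds 1 and 2 could not show, as each differs from compound 3 in more than one place. No measured property bears on this step, and what lies behind its size remains unknown.

Still open, as far as these compounds go, is whether a bromine, a nitrile or a trifluoromethyl group in place of the chlorine of 2-chloro-4-hydroxy-5-methoxyphenyl would also leave the number within the scatter of that of compound 4. Also open is whether the same exchange of rings would give a step of similar size on the side chain of compound 2, as no such pair stands among the compounds shown.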